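From 3-(trifluoromethyl)phenyl to 3,5-difluorophenyl on the sulfonyl sulfur

This account rests on a few compounds, and the source may have more. Where it says the series, first, only, none or still open, it means among the compounds named here.

Compound 1 `O=C(NCc1ccc(S(=O)(=O)c2cccc(C(F)(F)F)c2)cc1)c1cc2ccncc2o1`: 64%
Compound 2 `O=C(NCc1ccc(S(=O)(=O)c2cccc(C(F)(F)F)c2)cc1)c1cnc2nccn2c1`: 27%

In an ADME assay on microsomes from liver (Mus musculus) for metabolic stability, read by LC-MS, with a stated time of 30 min, tested at 1 uM (a higher number here means that more of the compound is left, a lower number that less of the compound is left), compound 1 stands highest of the two measured compounds at 64%. Compound 3 `O=C(NCc1ccc(S(=O)(=O)c2cc(F)cc(F)c2)cc1)c1cc2ccncc2o1` differs from it at the sulfonyl sulfur: 3,5-difluorophenyl in place of 3-(trifluoromethyl)phenyl on a sulfonyl sulfur, with 3,5-difluorophenyl in place of 3-(trifluoromethyl)phenyl. Within the data shown here, the only measured step, a number 37 percentage points lower from compound 1 to compound 2 (beyond the scatter), is large but changes the group on the carbonyl carbon, so no measured step tests this exchange directly. The estimated step is a number 4 percentage points lower from compound 1 to compound 3 (within the scatter), with no change beyond the scatter expected. For compound 3 the estimated value is 60%, with an expected range from 40% to 78%.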

Compound 3, percent of the compound remaining: 12%
The estimate for compound 3 lay 48 percentage points above the measured number; measured number below the stated range.
By their numbers in this assay, from the lowest: compound 3; then compound 2; then compound 1.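

In this assay, among these compounds, the earlier compounds showed a large step only at the carbonyl carbon; the sulfonyl sulfur now proves just as open to a large change. Exchanging 3-(trifluoromethyl)phenyl for 3,5-difluorophenyl gives a number 52 percentage points lower from compound 1 to compound 3 (beyond the scatter), although both groups are phenyl rings carrying fluorine. Nothing at hand accounts for this step.

As far as these compounds go, whether a chlorophenyl or a pyridyl group on the sulfonyl sulfur would retain more of the compound remains open. So does whether the same exchange would act alike on the carbonyl group of compound 2.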